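The compounds below may be only part of what the source reports. "The series", "measured", "known", "first", "only" and "open" are said of these compounds alone.

Compound 1 `CC(C)c1c(Cc2c(Cl)cccc2Cl)nc(SCC(=O)c2ccccc2)[nH]c1=O` | > 56000 nM | a limit
Compound 2 `CCc1c(Cc2c(F)cccc2Cl)nc(SCC(=O)c2ccccc2)[nH]c1=O` | > 12000 nM | a limit

Both entries come from an ADME assay on MT4 cells (Homo sapiens) for cytotoxicity, read by MTT assay (a lower number here means that less compound is tolerated, a higher number that more compound is tolerated), and neither is an exact number. Compound 2 has only the limit > 12000 nM to show for its standing. Compound 3 `CC(C)c1c(Cc2c(F)cccc2Cl)nc(SCC(=O)c2ccccc2)[nH]c1=O` differs from compound 2 by methyl in place of hydrogen on a saturated chain carbon bound to an aromatic carbon and a saturated chain carbon in the change from ethyl to isopropyl, with methyl in place of hydrogen on a saturated chain carbon bound to an aromatic carbon and a saturated chain carbon. Within the data shown here, no measured step guides this change, so no shift beyond the usual scatter is expected in this assay. The expected change a step that the limit leaves unreadable from compound 2 to compound 3 is therefore small. Compound 3 is estimated at 20000 nM with a likely range from 6000 nM to 60000 nM in this measurement.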

Compound 3, half-maximal cytotoxic concentration: > 12000 nM
Compound 3: no number, only a limit; the forecaster's own chance of this, stated with the estimate: 65%; the middle value is on the limit's open side.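

Among these compounds, compound 1, compound 2 and compound 3 all carry only limits in this assay, and no step from compound 1 or compound 2 to compound 3 can be read. Still open, from the compounds shown here alone, is the actual cytotoxic concentration of each compound, and whether ethyl to isopropyl or fluoro in place of chloro changes it.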